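Dimethylaminoacetate Ester Replacing a Sulfinyl Group

The source may report more compounds than this note shows. Statements on the series, on what has been measured and on what is new or still open speak of the compounds shown alone.

Compound 1, `Nc1ccc(-c2cc(=O)c3c(N)c(F)c(Br)c(F)c3o2)cc1F`, gives > 100000 nM in a functional assay on HeLa cells (Homo sapiens) for cytotoxicity, read by neutral red uptake, with a stated time of 3 days (on this read-out lower numbers stand for stronger inhibition and higher numbers for weaker inhibition), a limit of the assay and not a number.
Compound 2, `C[S+]([O-])c1c(F)c(N)c2c(=O)cc(-c3ccc(N)c(F)c3)oc2c1F`, gives > 100000 nM in this assay, again only a limit.
Compound 3, `CCC(=O)OCc1c(F)c(N)c2c(=O)cc(-c3ccc(N)c(F)c3)oc2c1F`, gives 69000 nM in this assay.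

Compound 2 therefore stands at the limit of > 100000 nM in this assay, at which 2 of the 3 values shown sit, and no number is known for it. Compound 4, `CN(C)CC(=O)OCc1c(F)c(N)c2c(=O)cc(-c3ccc(N)c(F)c3)oc2c1F`, is compound 2 with a group of 8 heavy atoms (5 carbon, 1 nitrogen, 2 oxygen; no ring) in place of a group of 3 heavy atoms (1 carbon, 1 oxygen, 1 sulfur; no ring), on an aromatic carbon. The measured step that the two limits leave unreadable from compound 1 to compound 2 is unreadable, while an at least 1.4-fold lower number from compound 2 to compound 3 (0.16 log units; that floor lies within the scatter) shows only a floor that lies within the scatter. Compound 3 carries a (propanoyloxy)methyl group on the same aromatic carbon, so compound 3 is the closest guide to compound 4. Compound 4 is expected to give 80000 nM, from 30000 nM to 200000 nM, an estimated step of an at least 1.2-fold lower number from compound 2 to compound 4 (0.09 log units; that floor lies within the scatter) that may again end at the limit.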

Compound 4, half-maximal inhibitory concentration: 9200 nM
Beside the measured number, compound 4's estimate is 8.7-fold (0.94 log units) above it; measured number outside the range, below it.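

For the compounds shown here, on this aromatic carbon, the ((((dimethylamino)methyl)carbonyl)oxy)methyl group gives the first steps beyond the scatter in this assay, with an at least 10-fold lower number from compound 2 to compound 4 (1.03 log units; beyond the scatter) and an at least 10-fold lower number from compound 1 to compound 4 (1.03 log units; beyond the scatter). Within the ester, dimethylamino in place of methyl on the saturated chain carbon bound to the carbonyl carbon gives a 7.5-fold lower number from compound 3 to compound 4 (0.88 log units; beyond the scatter), so among these compounds the ester alone does not account for the whole step. On these data alone, how a longer chain carrying the amine, or a carboxylic acid in place of dimethylamino, would read remains open. Compound 2 also stays a limit and not a number: the limit of > 100000 nM in this assay, at which 2 of the 4 values shown sit.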